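From Methyl to Ethylsulfonyl: Expected Tolerance of Compound 4

The source may report more compounds than this note shows. Statements on the series, on what has been measured and on what is new or still open speak of the compounds shown alone.

Of the compounds shown here, three sharing one core have been tested in an ADME assay on MT4 cells (Homo sapiens) for cytotoxicity, read by MTT assay, with a stated time of 5 days; a higher number here means that more compound is tolerated, a lower number that less compound is tolerated. Compound 1 `CN(c1ccnc(Nc2ccc(C#N)cc2)n1)c1c(F)cc(-c2ccc(C#N)cc2)cc1F` gives 148000 nM in this assay. Compound 2 `CCN(c1ccnc(Nc2ccc(C#N)cc2)n1)c1c(F)cc(-c2ccc(C#N)cc2)cc1F` gives 105000 nM, and compound 3 `N#CCN(c1ccnc(Nc2ccc(C#N)cc2)n1)c1c(F)cc(-c2ccc(C#N)cc2)cc1F` gives 206000 nM. Compound 1 sits close to both neighbours: a 1.4-fold higher number from compound 1 to compound 3 (0.14 log units; within the scatter), and a 1.4-fold lower number from compound 1 to compound 2 (0.15 log units; within the scatter). Between the other two, a 2.0-fold higher number from compound 2 to compound 3 (0.29 log units; within the scatter). None of these steps, which all alter the small group on the same chain carbon bound to the nitrogen, moves the number beyond the scatter of repeated measurements.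

Compound 4 `CCS(=O)(=O)N(c1ccnc(Nc2ccc(C#N)cc2)n1)c1c(F)cc(-c2ccc(C#N)cc2)cc1F` is not yet measured. It differs from compound 1 as follows: ethylsulfonyl in place of methyl on a nitrogen on an aromatic ring. Within the data shown here, no measured step swaps in a sulfonyl, so none bears on this change directly. Among the measured compounds shown here, the only guidance is that the three variations already made at this nitrogen, methyl, ethyl and cyanomethyl, left this assay essentially unchanged. On that basis, no step beyond the scatter is expected, in either direction, from compound 1 to compound 4: a 1.0-fold higher number from compound 1 to compound 4 (0.01 log units; within the scatter). Compound 4 is therefore estimated at 150000 nM in this assay, with a range from 60000 nM to 350000 nM, the range kept wide since the entering group is unlike anything measured here.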

Compound 4, half-maximal cytotoxic concentration: > 125000 nM
Compound 4 gave a limit, no number (the forecaster's own chance of this, stated with the estimate: 20%); the middle value does not contradict the limit.
By their numbers in this assay, from the lowest: compounds 2, 1 and 3 (each within the scatter of the next).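

In this assay the reading for compound 4 is a limit and not a number: the limit of > 125000 nM in this assay, at which 1 of the 4 values shown sits.

The steps to compound 4 from compound 1 and from compound 3 therefore cannot be read, and the only readable one is an at least 1.1-fold higher number from compound 2 to compound 4 (0.07 log units; that floor lies within the scatter). Even so, the result extends what was known about this nitrogen on an aromatic ring: the earlier compounds carried only methyl, ethyl and cyanomethyl there, whereas ethylsulfonyl brings 5 heavy atoms, including sulfur and 2 oxygen, and 2 hydrogen-bond acceptors, yet shows no loss against ethyl in this measurement.

The actual number for compound 4 remains open, so the compounds shown cannot settle how ethylsulfonyl compares with methyl or cyanomethyl at this position. Also open, as far as these compounds go, is how the assay responds to other groups on this nitrogen, such as a plain hydrogen, an acetyl, a methylsulfonyl or a longer chain such as butyl, which would show whether the result for ethylsulfonyl extends to close relatives.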